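The compounds below may be only part of what the source reports. "The series", "measured", "known", "first", "only" and "open" are said of these compounds alone.

The measured compounds so far:
compound 1, `Cc1cc(C2CCC2)c(S(C)(=O)=O)cc1C(=O)N=C(N)N`, giving 8.2 nM in a functional assay for inhibition of sodium/hydrogen exchanger (Oryctolagus cuniculus); a higher number here means a weaker inhibitor, a lower number a stronger inhibitor
compound 2, `Cc1cc(C2CCCCC2)c(S(C)(=O)=O)cc1C(=O)N=C(N)N`, giving 22 nM in this assay

Among these two, compound 2 has the highest number in this assay, and the single measured step is a 2.7-fold higher number from compound 1 to compound 2 (0.43 log units; beyond the scatter), a cyclohexyl in place of a cyclobutyl on the aromatic carbon of the shared core.

Compound 3, `Cc1cc(-c2ccc(Cl)cc2)c(S(C)(=O)=O)cc1C(=O)N=C(N)N`, has not yet been measured. It differs from compound 2 in one place: 4-chlorophenyl in place of cyclohexyl on an aromatic carbon. For the measured compounds named here, the only measured step that bears on this position is the one just described, and it concerned an exchange of one non-aromatic ring for another, which weakened inhibition modestly. Going by the values given here, the present change instead exchanges a non-aromatic ring for an aromatic ring carrying chlorine, and no measured step shows what such an exchange does here. The closest guide is simply the value of compound 2.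

Compound 3 is therefore expected to show a 1.1-fold higher number from compound 2 to compound 3 (0.06 log units; within the scatter), with no clear direction beyond the scatter. The estimate for compound 3 is 25 nM, within a range from 8 nM to 80 nM.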

Compound 3, half-maximal inhibitory concentration: 45 nM
The estimate for compound 3 lay 1.8-fold (0.26 log units) below the measured number, and the stated range covers the measured number.
By their numbers in this assay, from the lowest: compound 1; then compound 2; then compound 3.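

In this assay, an aromatic ring on this carbon, ortho to the methylsulfonyl group, still gives an inhibitor, and replacing cyclohexyl with 4-chlorophenyl produces a 2.0-fold higher number from compound 2 to compound 3 (0.31 log units; beyond the scatter). Measured against the smaller cyclobutyl ring, the same group gives a 5.5-fold higher number from compound 1 to compound 3 (0.74 log units; beyond the scatter), which is a larger step than either of the two single exchanges that connect these compounds through cyclohexyl, and the three groups now form an order running from cyclobutyl through cyclohexyl to 4-chlorophenyl, with each step modest but beyond the scatter. Nothing available explains why the number rises across this series, so the result describes the size of the change and not its cause.

The exchange from cyclohexyl to 4-chlorophenyl alters two things at once, the ring type and the presence of chlorine, and these compounds cannot separate the two contributions; a plain phenyl ring would be the direct link between them. On these data alone, it also remains open how this position responds to groups of a different kind, such as an amine, a carboxylic acid or an open chain like isopropyl.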